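Replacing the thiazolyl group of compound 3

A few compounds are considered here, and "the series" means these few. Any claim that something is new, unique, unknown or untested is made for them only; others in the source may bear on it.

In a functional assay on HeLa S3 cells (Homo sapiens) for cytotoxicity, read by XTT assay, with a stated time of 3 days (on this read-out higher numbers stand for weaker inhibition and lower numbers for stronger inhibition), compound 3 (`OC[C@H]1O[C@@H](n2cc(F)c3c(-c4nccs4)ncnc32)[C@H](O)[C@@H]1O`) gives 3100 nM and compound 1 (`OC[C@H]1O[C@@H](n2cc(F)c3c(-c4ccccc4)ncnc32)[C@H](O)[C@@H]1O`) gives 2600 nM within the scatter of it, while compound 2 (`OC[C@H]1O[C@@H](n2cc(F)c3c(-c4ccco4)ncnc32)[C@H](O)[C@@H]1O`) gives 8000 nM as the highest number of the three. Compound 3 therefore sits with compound 1, clearly lower than compound 2.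

Compound 4 (`OC[C@H]1O[C@@H](n2cc(F)c3c(-c4ccc[nH]4)ncnc32)[C@H](O)[C@@H]1O`) keeps the shared core and carries 1H-pyrrol-2-yl in place of 1,3-thiazol-2-yl on an aromatic carbon.

Three measured exchanges of this aromatic group bear on the change. Furan-2-yl for phenyl gives a 3.1-fold higher number from compound 1 to compound 2 (0.49 log units; beyond the scatter) and 1,3-thiazol-2-yl for furan-2-yl gives a 2.6-fold lower number from compound 2 to compound 3 (0.41 log units; beyond the scatter) as modest steps, and 1,3-thiazol-2-yl for phenyl gives a 1.2-fold higher number from compound 1 to compound 3 (0.08 log units; within the scatter) as no real step. No measurement with 1H-pyrrol-2-yl exists, so these steps only bound the expectation. The expected result in this assay is a 1.3-fold higher number from compound 3 to compound 4 (0.11 log units; within the scatter) with no estimated shift beyond the scatter in either direction. Compound 4 is estimated at 4000 nM (expected range 1500 nM to 11000 nM).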

Compound 4, half-maximal inhibitory concentration: 230 nM
The estimate for compound 4 lay 17-fold (1.24 log units) above the measured number; measured number below the stated range.
By their numbers in this assay, from the lowest: compound 4; then compounds 1 and 3 (each within the scatter of the next); then compound 2.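

In this assay, among these compounds, this place on an aromatic carbon of the shared core turns out to respond far more strongly to the choice of five-membered ring than the earlier compounds showed, since their steps were modest or within the scatter, while 1H-pyrrol-2-yl stands apart from all three other groups (a 13-fold lower number from compound 3 to compound 4 (1.13 log units; beyond the scatter); a 35-fold lower number from compound 2 to compound 4 (1.54 log units; beyond the scatter); an 11-fold lower number from compound 1 to compound 4 (1.05 log units; beyond the scatter)). Two groups of equal heavy-atom count can therefore read very differently here. The exchange replaces 0 hydrogen-bond donors with 1 hydrogen-bond donor, but nothing available ties that count or any other feature to the result.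

The compounds shown leave open whether a 1-methylpyrrol-2-yl or a 1H-imidazol-2-yl group would keep the low number of compound 4. They also do not tell how a methyl group on the carbons of the pyrrole ring would read.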